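This account rests on a few compounds, and the source may have more. Where it says the series, first, only, none or still open, it means among the compounds named here.

Working notes on the series

Of the compounds shown here, three share one core and have been measured in an assay on T47D cells for inhibition of Steryl-sulfatase (Homo sapiens), read by HPLC, with a stated time of 24 h; a lower number here means a stronger inhibitor, a higher number a weaker inhibitor. Compound 1 `Cc1ccccc1N(C)C(=O)c1ccc(-c2ccc(OS(N)(=O)=O)c(Cl)c2)o1` gives 25 nM in this assay. Compound 2 `Cc1ccccc1N(C)C(=O)c1ccc(-c2ccc(OS(N)(=O)=O)cc2F)o1` gives 12 nM. Compound 3 `Cc1cc(F)ccc1N(C)C(=O)c1ccc(-c2ccc(OS(N)(=O)=O)cc2)o1` gives 14 nM. Compound 3 stands with the second highest of the three numbers; its nearest neighbour is compound 2 and its furthest is compound 1, and both of those gaps fall within the usual scatter of this assay, so the three values are to be read as one cluster with no order among them.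

The next compound, compound 4 `Cc1ncccc1N(C)C(=O)c1ccc(-c2ccc(OS(N)(=O)=O)cc2)o1`, differs from compound 3 in a single place: 2-methylpyridin-3-yl in place of 4-fluoro-2-methylphenyl on an amide-type nitrogen. No measured pair in the series shows a change of this kind on the amide-type nitrogen, so there is no shown step to lean on. Given that the variations so far on this part of the molecule have all stayed within one cluster, the expected step of a 1.4-fold higher number from compound 3 to compound 4 (0.15 log units; within the scatter) is small and within the scatter, with no clear direction. For compound 4 a value of 20 nM is estimated in this assay, with a range from 8 nM to 50 nM.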

Compound 4, half-maximal inhibitory concentration: 270 nM
Compound 4: middle estimate off by 14-fold (1.13 log units), on the low side, and the stated range ends below it.
By their numbers in this assay, from the lowest: compounds 2, 3 and 1 (each within the scatter of the next, the first and the last beyond it); then compound 4.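

In this assay, for the compounds shown here, the group on the amide-type nitrogen now emerges as a place where the number can move a long way: 2-methylpyridin-3-yl in place of 4-fluoro-2-methylphenyl gives a 19-fold higher number from compound 3 to compound 4 (1.29 log units; beyond the scatter), the first step that can be read at all. The change looks modest as counted, since both groups are six-membered aromatic rings with no net charge and no hydrogen-bond donors, yet the entering group carries a ring nitrogen and a hydrogen-bond acceptor and the leaving group carries a fluorine, so a swap of this size is enough to weaken inhibition strongly in this series. Nothing available on these compounds bears on why the step is so large.

The step moves the fluorine and the ring nitrogen together, so the compounds shown do not separate the share of each. A plain 2-methylphenyl or a 4-fluoro-2-methylpyridin-3-yl on the same nitrogen, with the rest of compound 3 unchanged, would divide the step between the two, and a cyclohexyl there would test whether an aromatic ring is needed at all.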